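Acrylic acid to propiolic acid on the pyrazolylmethyl series

The compounds below may be only part of what the source reports. "The series", "measured", "known", "first", "only" and "open" are said of these compounds alone.

Measured so far:
Compound 1 `O=C(O)/C=C/c1ccc(Cn2cccn2)cc1OCCc1ccc2ccccc2c1`; in an assay on CHO cells for displacement of a labelled ligand from prostaglandin E2 receptor EP1 subtype (Mus musculus), read by scintillation counting (a higher number here means a weaker inhibitor, a lower number a stronger inhibitor), compound 1 gives 2900 nM.
Compound 2 `O=C(O)/C=C/c1ccc(Cn2ccnc2)cc1OCCc1ccc2ccccc2c1`; in this assay compound 2 gives > 10000 nM, a limit of the assay.
Compound 3 `O=C(O)/C=C/c1ccc(OCc2ccccc2)cc1OCCc1ccc2ccccc2c1`; in this assay compound 3 gives > 10000 nM, also a limit of the assay.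

Among the measured compounds shown here, compound 1 is thus the only compound of the three with a number; the other two sit at the limit of > 10000 nM in this assay, at which 2 of the 3 values shown sit. The two readable steps both concern the substituent on the far side of the core: an at least 3.4-fold higher number from compound 1 to compound 2 (0.53 log units; beyond the scatter) and an at least 3.4-fold higher number from compound 1 to compound 3 (0.53 log units; beyond the scatter), while a step that the two limits leave unreadable from compound 2 to compound 3. Compound 4 `O=C(O)C#Cc1ccc(Cn2cccn2)cc1OCCc1ccc2ccccc2c1` keeps the pyrazolylmethyl group and the naphthylethoxy chain of compound 1 and changes only the acid arm: 2-carboxyethynyl in place of 2-carboxyethenyl on an aromatic carbon. For the measured compounds named here, no measured step touches this arm, so there is nothing among the three compounds to read a direction from. The expectation is therefore a step of a 1.1-fold higher number from compound 1 to compound 4 (0.04 log units; within the scatter), that is, no change beyond the scatter, with wide uncertainty. Compound 4 is estimated at 3200 nM, ranging from 1100 nM to 9500 nM.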

Compound 4, inhibition constant: > 10000 nM
Compound 4: only a limit was reported; the forecaster's own chance of this, stated with the estimate: 25%; middle value at least 3.1-fold (0.49 log units) from the limit.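

The acid arm now has a measured step of its own: 2-carboxyethynyl in place of 2-carboxyethenyl gives an at least 3.4-fold higher number from compound 1 to compound 4 (0.53 log units; beyond the scatter). This aromatic carbon, ortho to a large group and para to a (1H-pyrazol-1-yl)methyl group, therefore does not tolerate every arm of 5 heavy atoms, even when the two arms differ only in a triple bond against a double bond. In this assay compound 4 gives > 10000 nM, which is a limit of the assay, and the set now gathers there: the limit of > 10000 nM in this assay, at which 3 of the 4 values shown sit.

Among the compounds shown here, how far the number rises with the 2-carboxyethynyl arm stays open, since compound 1 remains the only compound with a number. Also open, from the compounds shown here alone, is whether a saturated propanoic acid arm, a longer chain before the carboxylic acid, or a tetrazole in its place would give a number in this assay.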